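Para substituent on the pyrazoline aryl: trifluoromethyl to methoxy

The source may report more compounds than this note shows. Statements on the series, on what has been measured and on what is new or still open speak of the compounds shown alone.

Measured so far in a functional assay on MCF7 cells (Homo sapiens) for antiproliferative activity, read by MTT assay, with a stated time of 24 h; a higher number here means a weaker inhibitor, a lower number a stronger inhibitor:
Compound 1 `c1ccc(C2=NN(c3ccc(-c4ccccc4)nn3)C(c3ccccc3)C2)cc1`: 23800 nM
Compound 2 `Fc1ccc(C2CC(c3ccccc3)=NN2c2ccc(-c3ccccc3)nn2)cc1`: 100000 nM
Compound 3 `FC(F)(F)c1ccc(C2CC(c3ccccc3)=NN2c2ccc(-c3ccccc3)nn2)cc1`: 100000 nM

Compound 3 shares with compound 2 the highest of the three numbers; the step of no change at the digits printed from compound 2 to compound 3 (within the scatter), and a 4.2-fold higher number from compound 1 to compound 3 (0.62 log units; beyond the scatter). Compound 4 `COc1ccc(C2CC(c3ccccc3)=NN2c2ccc(-c3ccccc3)nn2)cc1` carries the change (methoxy in place of trifluoromethyl on an aromatic carbon). Within the data shown here, two measured steps bear on it: a 4.2-fold higher number from compound 1 to compound 2 (0.62 log units; beyond the scatter) and a 4.2-fold higher number from compound 1 to compound 3 (0.62 log units; beyond the scatter) show that each substituent placed on this ring so far raised the number by a similar modest amount, and no change at the digits printed from compound 2 to compound 3 (within the scatter) shows no difference between the two substituents tried. Methoxy is a third substituent at the same place; the expectation is that compound 4 stays near compound 3, so a 1.5-fold lower number from compound 3 to compound 4 (0.19 log units; within the scatter) is expected, with some chance of a partial return toward compound 1. Compound 4 is estimated at 65000 nM, range 20000 nM to 150000 nM.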

Compound 4, half-maximal inhibitory concentration: 100000 nM
For compound 4 the middle estimate is 1.5-fold (0.19 log units) below the measured one; measured number inside the range.
By their numbers in this assay, from the lowest: compound 1; then compounds 2, 3 and 4 (each within the scatter of the next).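

In this assay methoxy reads the same as trifluoromethyl (no change at the digits printed from compound 3 to compound 4 (within the scatter)) and as fluoro (no change at the digits printed from compound 2 to compound 4 (within the scatter)), so a hydrogen-bond acceptor in this place, absent from the other two groups, brings no visible difference. Compared with hydrogen, methoxy gives the same step as those two groups (a 4.2-fold higher number from compound 1 to compound 4 (0.62 log units; beyond the scatter)), so all three substituents now stand together, apart from compound 1. The data offer no measured explanation for this.

Open, from the compounds shown here alone, is whether an amine or a carboxylic acid at this carbon would move the number back toward compound 1. Also open, going by these compounds, is whether any substituent here can give a number lower than that of compound 1.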